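The source may report more compounds than this note shows. Statements on the series, on what has been measured and on what is new or still open speak of the compounds shown alone.

Of the compounds shown here, three built on one shared core have been tested in a functional assay on PC-3 cells (Homo sapiens) for cytotoxicity, read by MTT assay, with a stated time of 72 h; a higher number here means a weaker inhibitor, a lower number a stronger inhibitor. Compound 1 `COc1cc(Nc2nc3ccccc3nc2S(=O)(=O)c2ccc(C)cc2)cc(OC)c1` gives 2940 nM, compound 2 `COc1ccc(S(=O)(=O)c2nc3ccccc3nc2Nc2cc(OC)cc(OC)c2)cc1` gives 6220 nM, and compound 3 `COc1cc(Nc2nc3ccccc3nc2S(=O)(=O)c2ccc(Br)cc2)cc(OC)c1` gives 18200 nM, which is the highest number of the three, with both steps toward it beyond the scatter. Those two steps are a 6.2-fold higher number from compound 1 to compound 3 (0.79 log units; beyond the scatter) and a 2.9-fold higher number from compound 2 to compound 3 (0.47 log units; beyond the scatter). Compound 4 `COc1cc(Nc2nc3ccccc3nc2S(=O)(=O)c2ccc(F)cc2)cc(OC)c1` differs from compound 3 in a single place: fluoro in place of bromo on an aromatic carbon. Going by the values given here, no measured pair exchanges a bromo for a fluoro, so the two steps that end at compound 3 bear on the new change only indirectly: they show that among the three groups tried at this position, bromo gave the highest number, and that exchanging it for a smaller group has so far lowered the number. On that basis compound 4 is expected to give a somewhat lower number than compound 3, a 2.8-fold lower number from compound 3 to compound 4 (0.45 log units; beyond the scatter), although a result within the scatter cannot be ruled out. Compound 4 is estimated at 6500 nM, with a range from 2500 nM to 17000 nM.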

Compound 4, half-maximal inhibitory concentration: 4530 nM
Beside the measured number, compound 4's estimate is 1.4-fold (0.16 log units) above it; measured number inside the range.
By their numbers in this assay, from the lowest: compounds 1, 4 and 2 (each within the scatter of the next, the first and the last beyond it); then compound 3.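

The direct exchange gives a 4.0-fold lower number from compound 3 to compound 4 (0.60 log units; beyond the scatter) in this assay, so bromo now stands apart from three other groups at this position, not just from methyl and methoxy. Fluoro cannot be separated from either of those groups, with a 1.4-fold lower number from compound 2 to compound 4 (0.14 log units; within the scatter) and a 1.5-fold higher number from compound 1 to compound 4 (0.19 log units; within the scatter), although methyl and methoxy can be separated from each other. Nothing available explains why the bromo compound stands apart.

The compounds shown leave open what chloro, an amine or a carboxylic acid would give at this position, and so whether bromo is an isolated case. They also leave open whether the same exchange of bromo for fluoro would give a step of similar size on a different core.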